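Back to an Aromatic Ring on the Saturated Carbon

This account rests on a few compounds, and the source may have more. Where it says the series, first, only, none or still open, it means among the compounds named here.

Two measured compounds share one core and differ only in the group on a saturated ring carbon. Compound 1 `Cc1cc(O)c(C2=NN(c3ccc(S(N)(=O)=O)cc3)C(c3ccccc3O)C2)cc1Cl` carries a 2-hydroxyphenyl there, while compound 2 `Cc1cc(O)c(C2=NN(c3ccc(S(N)(=O)=O)cc3)C(/C=C/c3ccccc3)C2)cc1Cl` carries a 2-phenylethenyl. In a functional assay on NCI-H460 cells (Homo sapiens) for antiproliferative activity, with a stated time of 48 h (a higher number here means a weaker inhibitor of growth, a lower number a stronger inhibitor of growth), compound 1 gives 4480 nM, and compound 2 gives 17000 nM, which is the highest number of the two, placing compound 2 as the weaker inhibitor of growth. Compound 3 `COc1ccc(C2CC(c3cc(Cl)c(C)cc3O)=NN2c2ccc(S(N)(=O)=O)cc2)cc1OC` is not yet measured; it differs from compound 2 in that (3,4-dimethoxyphenyl in place of 2-phenylethenyl on a saturated ring carbon). For the measured compounds named here, the one step that bears on this change is a 3.8-fold higher number from compound 1 to compound 2 (0.58 log units; beyond the scatter), a modest move in the weakening direction; compound 3 reverses part of it, since the entering group is again a six-membered aromatic ring of carbon only, as in compound 1. For compound 3 a lowering of the number is therefore expected, roughly a 2.8-fold lower number from compound 2 to compound 3 (0.45 log units; beyond the scatter). Compound 3 is estimated to give 6000 nM, within 2500 nM to 15000 nM.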

Compound 3, concentration for total growth inhibition: 5850 nM
For compound 3 the middle estimate is 1.0-fold (0.01 log units) above the measured one; the range from low to high includes it.
By their numbers in this assay, from the lowest: compounds 1 and 3 (each within the scatter of the next); then compound 2.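

In this assay, the change to 3,4-dimethoxyphenyl gives a 2.9-fold lower number from compound 2 to compound 3 (0.46 log units; beyond the scatter), so on this saturated ring carbon a six-membered aromatic ring of carbon only, attached directly, goes with a lower number than 2-phenylethenyl in both comparisons available. The further comparison, a 1.3-fold higher number from compound 1 to compound 3 (0.12 log units; within the scatter), leaves 2-hydroxyphenyl and 3,4-dimethoxyphenyl indistinguishable here, which shows that a hydroxyl on this ring is not required for a number at this level, since 3,4-dimethoxyphenyl has no hydrogen-bond donors. Nothing available explains why these groups compare as they do.

The compounds shown leave open whether an unsubstituted phenyl would match these two rings, or whether a ring carrying a dimethylamino group or a carboxylic acid would. They also leave open how a saturated 2-phenylethyl chain would compare with 2-phenylethenyl.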